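Moving the chlorines on the benzyloxy arm of compound 3

The source may hold more compounds than are shown below. What is called first, only, known or untested is meant among the compounds shown, and "the series" means these compounds.

Measured compounds:
compound 1 `CO[C@@H]1C[C@@H]2[C@H]([C@]1(N)C(=O)O)[C@@]2(F)C(=O)O` — 39.2 nM
compound 2 `Nc1cccc(CO[C@@H]2C[C@@H]3[C@H]([C@]2(N)C(=O)O)[C@@]3(F)C(=O)O)c1` — 15.4 nM
compound 3 `N[C@]1(C(=O)O)[C@H]2[C@@H](C[C@H]1OCc1cc(Cl)cc(Cl)c1)[C@]2(F)C(=O)O` — 5.61 nM

In an assay on CHO cells for binding affinity to metabotropic glutamate receptor 2 (Rattus norvegicus) (on this read-out lower numbers stand for stronger inhibition and higher numbers for weaker inhibition), compound 3 holds the lowest number of the three measured compounds. Its nearest neighbour is compound 2 (a 2.7-fold lower number from compound 2 to compound 3 (0.44 log units; beyond the scatter)), and its most distant is compound 1 (a 7.0-fold lower number from compound 1 to compound 3 (0.84 log units; beyond the scatter)). Compound 4 `N[C@]1(C(=O)O)[C@H]2[C@@H](C[C@H]1OCc1c(Cl)cccc1Cl)[C@]2(F)C(=O)O` differs from compound 3 by 2,6-dichlorophenyl in place of 3,5-dichlorophenyl on a saturated chain carbon bound to an oxygen on a saturated carbon; the two have the same atoms, joined differently.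

No measured step bears directly on this change: every step shown (a 2.5-fold lower number from compound 1 to compound 2 (0.41 log units; beyond the scatter), a 7.0-fold lower number from compound 1 to compound 3 (0.84 log units; beyond the scatter), a 2.7-fold lower number from compound 2 to compound 3 (0.44 log units; beyond the scatter)) alters what group is carried, not where its chlorines sit. The steps only say that a dichlorinated aryl group at this place is associated with the lowest number seen. With no comparison between two arrangements of the same atoms, the expected step for compound 4 is uncertain in size and direction, and a modest rise in number is estimated, a 2.7-fold higher number from compound 3 to compound 4 (0.43 log units; beyond the scatter). Compound 4 is therefore expected to give about 15 nM in this assay, within a range of 4 nM to 60 nM.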

Compound 4, inhibition constant: 4.3 nM
Beside the measured number, compound 4's estimate is 3.5-fold (0.54 log units) above it, within the range that was stated.
By their numbers in this assay, from the lowest: compounds 4 and 3 (each within the scatter of the next); then compound 2; then compound 1.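

In this assay, compound 3 and compound 4 offer a direct comparison of two arrangements of the same atoms, and the change to 2,6-dichlorophenyl from 3,5-dichlorophenyl on a saturated chain carbon bound to an oxygen on a saturated carbon is a 1.3-fold lower number from compound 3 to compound 4 (0.12 log units; within the scatter), so this read-out does not separate the two arrangements. The other comparisons are a 3.6-fold lower number from compound 2 to compound 4 (0.55 log units; beyond the scatter) and a 9.1-fold lower number from compound 1 to compound 4 (0.96 log units; beyond the scatter), which shows that compound 4, like compound 3, stands clear of both other compounds. Nothing available explains why the two chlorine arrangements read alike here.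

The compounds shown leave open whether a single chlorine, bromine in place of each chlorine, or a carboxylic acid on the phenyl ring would give a similar number. From the compounds shown here alone, it also remains open whether a longer chain carrying 2,6-dichlorophenyl would do so.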